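Pyrrolopyridinyloxy anilides: swapping the aryl on ring nitrogen

The source may report more compounds than this note shows. Statements on the series, on what has been measured and on what is new or still open speak of the compounds shown alone.

Measured so far:
compound 1, `COc1ccc(-n2cc(C(=O)Nc3ccc(Oc4ccnc5[nH]ccc45)cc3)c(=O)c3ccccc32)cc1`: 5950 nM
compound 2, `O=C(Nc1ccc(Oc2ccnc3[nH]ccc23)c(F)c1)c1cn(-c2ccc(F)c(Cl)c2)c2ccccc2c1=O`: 3390 nM

In a functional assay on HepG2 cells (Homo sapiens) for inhibition, read by MTT assay, with a stated time of 72 h (on this read-out higher numbers stand for weaker inhibition and lower numbers for stronger inhibition), compound 1 gives 5950 nM. In this assay compound 2 gives 3390 nM. The two numbers sit within the usual scatter of each other, so neither compound can be called the stronger on this evidence. Compound 3, `COc1ccc(-n2cc(C(=O)Nc3ccc(Oc4ccnc5[nH]ccc45)c(F)c3)c(=O)c3ccccc32)cc1`, has not been measured. It differs from compound 2 by 4-methoxyphenyl in place of 3-chloro-4-fluorophenyl on an aromatic nitrogen. Because compound 1, which carries the same 4-methoxyphenyl, gives 5950 nM, the expected step of a 1.5-fold higher number from compound 2 to compound 3 (0.17 log units; within the scatter) is small and toward a weaker number, if it shows beyond the scatter at all. Compound 3 is therefore estimated at 5000 nM, between 2000 nM and 13000 nM.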

Compound 3, half-maximal inhibitory concentration: 6530 nM
Compound 3: middle estimate off by 1.3-fold (0.12 log units), on the low side; the measured number falls inside the stated range.
By their numbers in this assay, from the lowest: compounds 2, 1 and 3 (each within the scatter of the next).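

In this assay, within the data shown here, 4-methoxyphenyl in place of 3-chloro-4-fluorophenyl on the aromatic nitrogen gives a 1.9-fold higher number from compound 2 to compound 3 (0.28 log units; within the scatter) and so offers the first one-place comparison at this position, which does not separate the two aryl groups. With the 4-methoxyphenyl kept, fluoro in place of hydrogen on an aromatic carbon gives a 1.1-fold higher number from compound 1 to compound 3 (0.04 log units; within the scatter) and likewise shows no difference beyond the scatter. No supporting measurement bears on either step.

From the compounds shown here alone, whether an amine or a carboxylic acid on this aryl, or a longer chain in its place on the aromatic nitrogen, would move the number beyond the scatter stays open.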